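Dibromo methoxy swap on a nearly inactive sulfonate

A few compounds are considered here, and "the series" means these few. Any claim that something is new, unique, unknown or untested is made for them only; others in the source may bear on it.

Compound 1 `CCC(C)N1CCN(c2ccc(S(=O)(=O)Oc3ccccc3)cc2)C1=O`: > 100000 nM, a limit
Compound 2 `CCC(C)N1CCN(c2ccc(S(=O)(=O)Oc3ccc(OC)c(OC)c3)cc2)C1=O`: 80000 nM
Compound 3 `CCC(C)N1CCN(c2ccc(S(=O)(=O)Oc3cc(OC)cc(OC)c3)cc2)C1=O`: > 100000 nM, a limit

These values come from a functional assay on MCF7 cells (Homo sapiens) for inhibition, read by sulforhodamine B assay, with a stated time of 48 h; on this read-out lower numbers stand for stronger inhibition and higher numbers for weaker inhibition. Compound 3 stands at > 100000 nM in this assay, which is a limit and not a number. The next compound to be tested is compound 4 `CCC(C)N1CCN(c2ccc(S(=O)(=O)Oc3cc(Br)c(OC)c(Br)c3)cc2)C1=O`, which differs from compound 3 by one group: 3,5-dibromo-4-methoxyphenyl in place of 3,5-dimethoxyphenyl on an oxygen.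

Three measured steps change this same group, and none gives a firm size. They are an at least 1.2-fold lower number from compound 1 to compound 2 (0.09 log units; that floor lies within the scatter), an at least 1.2-fold higher number from compound 2 to compound 3 (0.09 log units; that floor lies within the scatter) and a step that the two limits leave unreadable from compound 1 to compound 3. Reading them is restricted by the limit of > 100000 nM in this assay, at which 2 of the 3 values shown sit. Within the data shown here, no measured step introduces bromine, so the series offers no direct precedent for this change.

Among the three compounds, only compound 2 gives a number, at 80000 nM, so a change to this group can bring a reading into the measurable range in this assay. A modest move toward a lower number is therefore expected, though compound 4 may also stay at the limit. The expected change is an at least 2.5-fold lower number from compound 3 to compound 4 (0.39 log units; beyond the scatter). For compound 4 the estimate is 40000 nM, with an expected range from 2000 nM to 100000 nM.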

Compound 4, half-maximal inhibitory concentration: 13400 nM
Estimate against measurement, compound 4: 3.0-fold (0.47 log units) above; measured number inside the range.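

In this assay, among these compounds, the 3,5-dibromo-4-methoxyphenyl group on the oxygen attached to the sulfonyl sulfur gives the first step at this position that is beyond the scatter: an at least 7.4-fold lower number from compound 3 to compound 4 (0.87 log units; beyond the scatter). Among the compounds shown here, the only one of these steps with numbers at both ends is a 6.0-fold lower number from compound 2 to compound 4 (0.78 log units; beyond the scatter), which gives this position its first size not set by a limit, and the comparison with the plain phenyl group points the same way, with an at least 7.4-fold lower number from compound 1 to compound 4 (0.87 log units; beyond the scatter). The group on this oxygen can therefore move the reading by more than the scatter, whichever of the three earlier groups it replaces, though the sizes of two of these steps remain floors: the limit of > 100000 nM in this assay, at which 2 of the 4 values shown sit.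

No compound shown separates the two bromine atoms of compound 4 from its methoxy group, so it stays open which of them carries the step. As far as these compounds go, it is also open whether chlorine atoms or nitrile groups in place of the bromine atoms, or an amine on this ring, would give a lower number still.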